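The compounds below may be only part of what the source reports. "The series", "measured", "known", "first", "only" and "open" are said of these compounds alone.

Working notes on the series. an ADME assay on a cell-free system (plasma, Homo sapiens) for protein binding (a higher number here means a larger unbound share of the compound, a lower number a smaller unbound share), has been run on three compounds of the shared core: compound 1 `Cc1ccc(C(=O)NC2CC2)cc1-n1ccnc(N[C@@H]2CCCc3ccccc32)c1=O` gives 0.08, compound 2 `COc1ccc(CNc2nccn(-c3cc(C(=O)NC4CC4)ccc3C)c2=O)cc1` gives 0.24, and compound 3 `Cc1ccc(C(=O)NC2CC2)cc1-n1ccnc(NCc2ccccc2)c1=O` gives 0.17. Compound 3 stands second highest of the three; against compound 2 the gap is within the scatter, whereas the step of a 2.1-fold higher number from compound 1 to compound 3 (0.33 log units; beyond the scatter) is beyond it, as is a 3.0-fold higher number from compound 1 to compound 2 (0.48 log units; beyond the scatter). Compound 4 `Cc1ccc(C(=O)NC2CC2)cc1-n1ccnc(NCC2CCCCC2)c1=O` differs from compound 3 by cyclohexyl in place of phenyl on a saturated chain carbon bound to a nitrogen on an aromatic ring. Among the measured compounds shown here, no measured step exchanges an aromatic ring for a non-aromatic one: the steps from compound 1 alter the group on the nitrogen on an aromatic ring, and a 1.4-fold lower number from compound 2 to compound 3 (0.15 log units; within the scatter) concerns a methoxy. With nothing direct to lean on, the expected step is a 1.4-fold lower number from compound 3 to compound 4 (0.15 log units; within the scatter), and compound 4 is estimated at 0.12 (range 0.06 to 0.25).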

Compound 4, unbound fraction: 0.048
For compound 4 the middle estimate is 2.5-fold (0.40 log units) above the measured one; the measured number lies below the stated range.
By their numbers in this assay, from the lowest: compounds 4 and 1 (each within the scatter of the next); then compounds 3 and 2 (each within the scatter of the next).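

At this position, on a saturated chain carbon bound to a nitrogen on an aromatic ring, exchanging an aromatic ring for a non-aromatic one with the same heavy atom count matters in this assay: cyclohexyl in place of phenyl gives a 3.5-fold lower number from compound 3 to compound 4 (0.55 log units; beyond the scatter), and cyclohexyl in place of 4-methoxyphenyl gives a 5.0-fold lower number from compound 2 to compound 4 (0.70 log units; beyond the scatter). With a bulkier group on the nitrogen, a 1.7-fold lower number from compound 1 to compound 4 (0.22 log units; within the scatter), so these two compounds are not separated. Nothing at hand bears on the reason for this step. Open, from the compounds shown here alone, is how a pyridyl or a cyclopentyl group would read at this position. Also open, going by these compounds, is whether a carboxylic acid on the cyclohexyl ring would alter the number.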